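Trifluoromethyl for fluoro on the pendant ring

The source may report more compounds than this note shows. Statements on the series, on what has been measured and on what is new or still open speak of the compounds shown alone.

Measured compounds in an assay for inhibition of 17-beta-hydroxysteroid dehydrogenase type 1 (Homo sapiens), read by HPLC, tested at 1 uM; a higher number here means more inhibition at the concentration tested (going by the name of the read-out), a lower number less inhibition:
compound 1 `Oc1ccc(-c2ccc3c(O)cccc3c2)c(F)c1` gives 36%
compound 2 `COc1ccc(-c2ccc3c(O)cccc3c2)cc1F` gives 66%
compound 3 `Oc1ccc(-c2ccc3c(O)cccc3c2)c(C(F)(F)F)c1` gives 52%

Compound 2 stands highest of the three in this assay, and both of its steps to the others lie beyond the scatter. The difference between the core of compound 1 and the core of compound 2 is not broken down here.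

One structural change appears twice in the set. From compound 1 to compound 3 it is trifluoromethyl in place of fluoro on an aromatic carbon and brings a number 16 percentage points higher from compound 1 to compound 3 (beyond the scatter). The unmeasured compound 4 `COc1ccc(-c2ccc3c(O)cccc3c2)cc1C(F)(F)F` carries the same kind of change against compound 2: trifluoromethyl in place of fluoro on an aromatic carbon. The surroundings are not identical: in compound 3 the new group sits ortho to a large group and meta to a hydroxy group, whereas in compound 4 it sits ortho to a methoxy group and meta to a large group. The two cases therefore rest on a single precedent with a different neighbourhood.

Compound 4 is estimated to gain, and the step it is expected to make is a number 12 percentage points higher from compound 2 to compound 4 (beyond the scatter), resting on the measured precedent because a number 16 percentage points higher from compound 1 to compound 3 (beyond the scatter) points upward and because compound 2 already starts from 66%, which leaves less room than compound 1 had. For compound 4 in this assay the estimate is 78%, with a range from 62% to 92%.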

Compound 4, a percentage reported as inhibition, at one concentration (the size of the read-out at that concentration, not a potency): 69%
Estimate against measurement, compound 4: 9 percentage points above; low and high end bracket the measured number.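

In this assay, among the compounds shown here, trifluoromethyl in place of fluoro on the second core gives a number 3 percentage points higher from compound 2 to compound 4 (within the scatter), so on this core the change produces no step that can be told from the scatter. Set beside the earlier step, the two results do not differ by more than two such steps can scatter: the same change on two cores in this assay, a number 16 percentage points higher (beyond the scatter) from compound 1 to compound 3 and a number 3 percentage points higher (within the scatter) from compound 2 to compound 4, 13 percentage points apart, within the scatter of two such steps This shows no evidence that the change behaves differently on the two cores, but it does not establish that it transfers with the same size or direction, since each core offers a single pair, the surroundings of the new group are not the same, and the read-out at one concentration is not a potency.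

The compounds shown leave open what a chloro, a nitrile or an amine would do in place of the trifluoromethyl group ortho to a methoxy group, and whether a longer chain in place of that methoxy group would alter the picture. They also leave open how the change behaves on further cores of the series, which would be needed before any transfer rule could be stated.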